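From compound 2 to compound 3: a swap on the amide

The source may report more compounds than this note shows. Statements on the series, on what has been measured and on what is new or still open speak of the compounds shown alone.

Compound 1 `N#Cc1ccc(Nc2nccc(OCC(=O)Nc3cccc(Cl)c3)n2)cc1`: > 329000 nM (a limit)
Compound 2 `Cc1cc(OCC(=O)Nc2ccc(Br)cc2)nc(Nc2ccc(C#N)cc2)n1`: 930 nM

Among the measured compounds shown here, in an ADME assay on MT4 cells (Homo sapiens) for cytotoxicity, read by MTT assay, with a stated time of 5 days (a higher number here means that more compound is tolerated, a lower number that less compound is tolerated), compound 2 stands at 930 nM, the only actual number so far. Compound 1 gives only a limit of the assay, > 329000 nM.

Compound 3 `Cc1cc(OCC(=O)Nc2cccc(Cl)c2)nc(Nc2ccc(C#N)cc2)n1` has not yet been measured. Its difference from compound 2 is this: 3-chlorophenyl in place of 4-bromophenyl on an amide-type nitrogen. In short, 3-chlorophenyl stands in place of 4-bromophenyl on an amide-type nitrogen. For the measured compounds named here, no measured step isolates this change. Compound 3 does share the 3-chlorophenyl with compound 1, whose value of > 329000 nM is a limit. The step of a 22-fold higher number from compound 2 to compound 3 (1.33 log units; beyond the scatter) is therefore expected to go upward, toward more compound tolerated and beyond the scatter, though its size is uncertain. In this assay compound 3 is estimated at 20000 nM, with an expected range from 2000 nM to 300000 nM.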

Compound 3, half-maximal cytotoxic concentration: 32200 nM
For compound 3 the middle estimate is 1.6-fold (0.21 log units) below the measured one; measured number inside the range.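

In this assay, the amide-type nitrogen now has its first measured step, and the swap of 4-bromophenyl for 3-chlorophenyl there is large: a 35-fold higher number from compound 2 to compound 3 (1.54 log units; beyond the scatter). With the 3-chlorophenyl held fixed, methyl in place of hydrogen on an aromatic carbon also moves the number, here toward less compound tolerated: an at least 10-fold lower number from compound 1 to compound 3 (1.00 log units; beyond the scatter). The size of this second step is only a bound, since compound 1 stands at a limit of the assay and not at a number: the limit of > 329000 nM in this assay, at which 1 of the 3 values shown sits.

The first step replaces the whole group, so the compounds shown do not separate the change of halogen from the change in its place on the ring. As far as these compounds go, how a plain phenyl on the amide-type nitrogen, or an ethyl in place of the methyl, would fall remains open.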